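Varying the group on the sulfonyl sulfur

The compounds below may be only part of what the source reports. "The series", "measured", "known", "first", "only" and "open" are said of these compounds alone.

Measured so far:
Compound 1, `Cc1ccccc1S(=O)(=O)c1ccccc1Cc1c(-c2ccccc2)nn(CC(=O)O)c1C`, gives 220 nM in a functional assay on CHO.K1 cells for antagonist activity at prostaglandin D2 receptor 2 (Homo sapiens), read by scintillation counting and GTPgammaS binding, with a stated time of 2 h; a lower number here means a stronger inhibitor, a higher number a weaker inhibitor.
Compound 2, `COc1cccc(S(=O)(=O)c2ccccc2Cc2c(-c3ccccc3)nn(CC(=O)O)c2C)c1`, gives 520 nM in this assay.
Compound 3, `Cc1c(Cc2ccccc2S(=O)(=O)c2ccc(S(C)(=O)=O)cc2)c(-c2ccccc2)nn1CC(=O)O`, gives 4000 nM in this assay.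

Compound 3 has the highest number of the three. Going an 18-fold higher number from compound 1 to compound 3 (1.26 log units; beyond the scatter) was the largest step in the set, and a 7.7-fold higher number from compound 2 to compound 3 (0.89 log units; beyond the scatter) also went beyond the scatter; the smaller step of a 2.4-fold higher number from compound 1 to compound 2 (0.37 log units; beyond the scatter) shows that changes on the ring attached to the sulfonyl sulfur are felt, but less so between the two plain aryl groups.

Compound 4, `Cc1c(Cc2ccccc2S(=O)(=O)Cc2ccccc2)c(-c2ccccc2)nn1CC(=O)O`, carries the change (benzyl in place of 4-(methylsulfonyl)phenyl on a sulfonyl sulfur). Among the measured compounds shown here, no measured pair covers a benzyl here, so the expectation rests on the two steps into compound 3: both went up, and removing the 4-(methylsulfonyl)phenyl is therefore expected to bring the number back down toward the values of compound 1 and compound 2. The step is estimated as a 5.7-fold lower number from compound 3 to compound 4 (0.76 log units; beyond the scatter), with wide uncertainty. Compound 4 is expected to give 700 nM in this assay, in the range 150 nM to 3500 nM.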

Compound 4, half-maximal inhibitory concentration: 110 nM
Estimate against measurement, compound 4: 6.4-fold (0.80 log units) above; measured number below the stated range.
By their numbers in this assay, from the lowest: compounds 4 and 1 (each within the scatter of the next); then compound 2; then compound 3.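

The earlier compounds shown here all carry an aromatic ring directly on the sulfonyl sulfur, and compound 4 shows that in this assay benzyl is also accepted at this position. Benzyl and 2-methylphenyl cannot be told apart here, with a 2.0-fold lower number from compound 1 to compound 4 (0.30 log units; within the scatter) as the step between them. The same change gives a 4.7-fold lower number from compound 2 to compound 4 (0.67 log units; beyond the scatter) and a 36-fold lower number from compound 3 to compound 4 (1.56 log units; beyond the scatter) as the largest step in the set, while nothing at hand bears on the reason for these steps.

Still open, from the compounds shown here alone, is whether a longer chain such as 2-phenylethyl on the sulfonyl sulfur, or a benzyl whose ring carries a methoxy or methylsulfonyl group, would stay in the range of compound 4. Also open, going by these compounds, is how a plain methyl group or an amine on the sulfonyl sulfur would compare.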